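A few compounds are considered here, and "the series" means these few. Any claim that something is new, unique, unknown or untested is made for them only; others in the source may bear on it.

Three compounds were tested in an ADME assay on the whole organism (strain Sprague-Dawley) for pharmacokinetics, with Rattus norvegicus as the target, using cassette dosing; on this read-out lower numbers stand for slow clearance and higher numbers for fast clearance:
compound 1 `O=C(C[C@]1(O)CC[C@H](Cc2ccccc2)CC1)Nc1ccc2[nH]c(=O)oc2c1` gives 35.1 mL/min/kg;
compound 2 `O=C(C[C@]1(O)CC[C@@H](Cc2ccc(F)cc2)CC1)Nc1ccc2[nH]c(=O)oc2c1` gives 36.8 mL/min/kg;
compound 3 `O=C(C[C@]1(O)CC[C@@H](Cc2ccc(Cl)cc2)CC1)Nc1ccc2[nH]c(=O)oc2c1` gives "not determined" (no result reported), that is, no reported result.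

Of the two numbers, compound 2 and compound 1 lie within the usual scatter of each other, so neither stands apart. Among the compounds with values here, no pair of measured compounds differs in only one place, so no measured step is available to guide a prediction. Compound 4 `O=C(C[C@]1(O)CC[C@@H](Cc2ccc(OC(F)(F)F)cc2)CC1)Nc1ccc2[nH]c(=O)oc2c1` is not yet measured. It differs from compound 2 as follows: trifluoromethoxy in place of fluoro on an aromatic carbon. With nothing comparable to lean on, the change from compound 2 to compound 4 is expected to bring no shift beyond the scatter in this assay, an estimated step of a 1.0-fold higher number from compound 2 to compound 4 (0.01 log units; within the scatter). Compound 4 is therefore expected to give 38 mL/min/kg, within a range from 22 mL/min/kg to 65 mL/min/kg.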

Compound 4, clearance: 21 mL/min/kg
Estimate against measurement, compound 4: 1.8-fold (0.26 log units) above; measured number outside the range, below it.
By their numbers in this assay, from the lowest: compounds 4, 1 and 2 (each within the scatter of the next).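

In this assay, within the data shown here, the change to trifluoromethoxy in place of fluoro, on an aromatic carbon para to a large group, gives a 1.8-fold lower number from compound 2 to compound 4 (0.24 log units; within the scatter) and provides the first measured step at this position. Clearance at this position therefore stays within the usual scatter even when a single fluorine gives way to a much larger group. No measurement at hand explains this step.

Three compounds cannot show how far this holds. As far as these compounds go, whether an amine or a carboxylic acid at the same position would also leave clearance within the scatter remains open.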